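Shifting the Chlorine on a Chlorophenyl Group

A few compounds are considered here, and "the series" means these few. Any claim that something is new, unique, unknown or untested is made for them only; others in the source may bear on it.

Compound 1, `Nc1scc(-c2ccccc2)c1C(=O)c1ccccc1`: 49%
Compound 2, `Nc1scc(-c2cccc(Cl)c2)c1C(=O)c1ccccc1`: 45%

Both compounds were tested in a functional assay on CHO cells for agonist activity at adenosine receptor A1 (Homo sapiens), read by fluorescence and ERK phosphorylation, with stated times of 30 min and 1.5 h, tested at 3 uM; on this read-out higher numbers stand for a stronger effect at the one concentration tested and lower numbers for a weaker effect. Compound 1 gives 49%, and compound 2 gives 45%. Going by the values given here, the only measured step is a number 4 percentage points lower from compound 1 to compound 2 (within the scatter), so compound 2 stands lowest of the two numbers, but its gap to compound 1 is within the scatter and does not rank the two.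

Compound 3, `Nc1scc(-c2ccc(Cl)cc2)c1C(=O)c1ccccc1`, has not yet been measured. It differs from compound 2 in one place: 4-chlorophenyl in place of 3-chlorophenyl on an aromatic carbon. Among the compounds with values here, no measured step covers this change; the one measured step only shows that adding a chlorine to give the 3-chlorophenyl group left the read-out essentially unchanged, a number 4 percentage points lower from compound 1 to compound 2 (within the scatter). With nothing pointing either way, no step beyond the scatter is expected in this assay from compound 2 to compound 3, and the estimated step is no change at the digits printed from compound 2 to compound 3 (within the scatter). Compound 3 is therefore expected to give about 45% in this assay, with a range from 25% to 65%.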

Compound 3, a percentage reported as activity, at one concentration (the size of the read-out at that concentration, not a potency): 46%
Compound 3: middle estimate off by 1 percentage points, on the low side, within the range that was stated.
By their numbers in this assay, from the lowest: compounds 2, 3 and 1 (each within the scatter of the next).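

In this assay, taking the chlorine from the 3-chlorophenyl group to the 4-chlorophenyl group, on the same aromatic carbon of the five-membered ring, gives a number 1 percentage points higher from compound 2 to compound 3 (within the scatter). Compared with the plain phenyl group, the 4-chlorophenyl group gives a number 3 percentage points lower from compound 1 to compound 3 (within the scatter), so compounds 1, 2 and 3 cannot be told apart on this read-out, and the two chlorine placements shown make no difference that can be read here. No supporting measurement bears on why these three compounds read alike, so the result can only be recorded as it stands.

The compounds shown leave open whether a different kind of group on this phenyl ring, such as an amine, a carboxylic acid or a longer alkyl chain, would give a step beyond the scatter. They also leave open whether these three compounds would still read alike at other concentrations: the read-out gives only the size of the effect at the one concentration tested.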